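The source may hold more compounds than are shown below. What is called first, only, known or untested is meant among the compounds shown, and "the series" means these compounds.

The measured compounds:

Compound 1, `C[C@H](c1ccccc1)N1C(=O)O[C@](Cc2ccccc2)(c2nnc(-c3ccccc3)o2)C1=O`: 0% in an ADME assay (liver) for metabolic stability, with Liver microsome (Rattus norvegicus) as the target, using microsomes, with a stated time of 0.5 h, tested at 1 uM; on this read-out higher numbers stand for a more stable compound and lower numbers for a less stable compound
Compound 2, `C[C@H](c1ccccc1)N1C(=O)O[C@](Cc2ccccc2)(c2nnc(Cc3ccccc3)o2)C1=O`: 0% in this assay

In this assay compound 2 stands level with compound 1, and the step from compound 1 to compound 2 is no change at the digits printed from compound 1 to compound 2 (within the scatter), a change of benzyl in place of phenyl on an aromatic carbon that left the read-out where it was.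

Compound 3, `C[C@H](c1ccccc1)N1C(=O)O[C@](Cc2ccccc2)(c2nnc(-c3cc(F)cc(F)c3)o2)C1=O`, is not yet measured. It differs from compound 2 by 3,5-difluorophenyl in place of benzyl on an aromatic carbon. Going by the values given here, the only measured step touching this position, no change at the digits printed from compound 1 to compound 2 (within the scatter), is the one just described, and it gives no sign that this carbon responds to what is attached there; no measured step involves a fluorinated group. Compound 3 is therefore expected to remain close to compound 2, with a step of a number 3 percentage points higher from compound 2 to compound 3 (within the scatter) in this assay. For compound 3 the estimate is 3%, with a range from 0% to 20%.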

Compound 3, percent of the compound remaining: 1%
Compound 3: middle estimate off by 2 percentage points, on the high side; the range from low to high includes it.
By their numbers in this assay, from the lowest: compounds 1, 2 and 3 (each within the scatter of the next).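

Putting 3,5-difluorophenyl on the aromatic carbon gives, in this assay, a number 1 percentage points higher from compound 2 to compound 3 (within the scatter), and measured against phenyl it gives a number 1 percentage points higher from compound 1 to compound 3 (within the scatter). The position has now carried phenyl, benzyl and a fluorinated phenyl with all three compounds within the scatter of one another, so the earlier flat reading extends to a group bearing fluorine, though all three sit so low that the read-out has little room to show a fall. Nothing at hand offers an explanation for this reading.

As far as these compounds go, whether an amine or a carboxylic acid on this carbon would lift the read-out from that low level stays open. The rest of the shared core is identical across all three compounds, so what its other groups contribute cannot be told.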